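Chain to Ring Swap: Expected Cytotoxicity of Compound 4

The compounds below may be only part of what the source reports. "The series", "measured", "known", "first", "only" and "open" are said of these compounds alone.

Compound 1 `CCCCCCCCc1cc(-c2cn([C@H]3C[C@H](O)[C@@H](CO)O3)c(=O)[nH]c2=O)on1` gives 3000 nM in an ADME assay on HeLa cells (Homo sapiens) for cytotoxicity; on this read-out lower numbers stand for higher toxicity in this test and higher numbers for lower toxicity in this test.
Compound 2 `CCCCCc1cc(-c2cn([C@H]3C[C@H](OC(C)=O)[C@@H](COC(C)=O)O3)c(=O)[nH]c2=O)on1` gives 3000 nM in this assay.
Compound 3 `CC(C)(C)c1ccc(-c2cc(-c3cn([C@H]4C[C@H](O)[C@@H](CO)O4)c(=O)[nH]c3=O)on2)cc1` gives 3000 nM in this assay.

Compound 2 stands level with compounds 1 and 3 within the scatter. The new compound 4 `CC(=O)OC[C@H]1O[C@@H](n2cc(-c3cc(-c4ccc(C(C)C)cc4)no3)c(=O)[nH]c2=O)C[C@@H]1OC(C)=O` differs from compound 2 in one place: 4-isopropylphenyl in place of pentyl on an aromatic carbon. Among the compounds with values here, one measured step bears on this, a chain replaced by a substituted phenyl on the same aromatic carbon: no change at the digits printed from compound 1 to compound 3 (within the scatter). That step lay within the scatter, so no shift beyond the scatter is expected here either, in either direction. For compound 4 the value in this assay is therefore estimated at 3000 nM, with a range from 1500 nM to 6000 nM, which means an expected step of no change at the digits printed from compound 2 to compound 4 (within the scatter).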

Compound 4, half-maximal cytotoxic concentration: 3000 nM
Beside the measured number, compound 4's estimate shows no gap at the digits printed, and the stated range covers the measured number.
By their numbers in this assay, from the lowest: compounds 1, 2, 3 and 4 (each within the scatter of the next).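

In this assay, the swap of pentyl for 4-isopropylphenyl gives no change at the digits printed from compound 2 to compound 4 (within the scatter). The earlier swap of a chain for a substituted phenyl was seen on a core with free hydroxyl groups, and this one shows the same flat outcome on a core carrying two acetate esters. No measurement shown here offers an explanation for this flat result. On these data alone, every group at this aromatic carbon so far contains only carbon, and whether an amine or a carboxylic acid there would shift the value remains open.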